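A few compounds are considered here, and "the series" means these few. Any claim that something is new, unique, unknown or untested is made for them only; others in the source may bear on it.

Three compounds have been measured in an ADME assay on microsomes from liver (Homo sapiens) for metabolic stability, tested at 2.5 uM; a lower number here means slower removal, a higher number faster removal of the compound:

Compound 1, `O=S(=O)(c1cc(Cl)cc(Cl)c1)c1cnc2cc(F)ccc2c1-c1ccc(Cl)cc1`, gives 0.13 mL/min.
Compound 2, `COc1ccc(S(=O)(=O)c2cnc3cc(F)ccc3c2-c2ccc(Cl)cc2)cc1`, gives 1.28 mL/min.
Compound 3, `O=S(=O)(c1cc(Cl)cc(Cl)c1)c1cnc2cc(F)ccc2c1-c1cccc(F)c1`, gives 0.41 mL/min.

Compound 4, `COc1ccc(S(=O)(=O)c2cnc3cc(F)ccc3c2-c2cccc(F)c2)cc1`, has not yet been measured in this assay. It differs from compound 3 in one place: 4-methoxyphenyl in place of 3,5-dichlorophenyl on a sulfonyl sulfur. This is the same change that separates compound 2 from compound 1, namely (4-methoxyphenyl in place of 3,5-dichlorophenyl on a sulfonyl sulfur), and the place lines of the two changes agree word for word, so the two changes are the same. Measured in this assay, that change produced a 9.8-fold higher number from compound 1 to compound 2 (0.99 log units; beyond the scatter), a step that lies beyond the usual scatter.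

The two cores on which the change is made are not identical. Compound 3 differs from compound 1 by 3-fluorophenyl in place of 4-chlorophenyl on an aromatic carbon, and in this assay this gives a 3.2-fold higher number from compound 1 to compound 3 (0.50 log units; beyond the scatter). Compound 3 therefore stands with the second highest of the three measured numbers, between compound 1 and compound 2.

Among the compounds with values here, whether the change from compound 3 to compound 4 repeats the size seen from compound 1 to compound 2 rests only on that single earlier pair; no second example on a different core has been measured. On that basis, the step from compound 3 to compound 4 in this assay is expected to be about an 8.5-fold higher number from compound 3 to compound 4 (0.93 log units; beyond the scatter), somewhat tempered because the starting number of compound 3 is already 0.41 mL/min. Compound 4 is therefore estimated at 3.5 mL/min, with a likely range from 1.5 mL/min to 8 mL/min.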

Compound 4, intrinsic clearance in a liver preparation (reported as CLH), per the amount of preparation that the assay uses: 2.94 mL/min
Compound 4: middle estimate off by 1.2-fold (0.08 log units), on the high side, within the range that was stated.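

In this assay, putting 4-methoxyphenyl in place of 3,5-dichlorophenyl on the sulfonyl sulfur gives a 7.2-fold higher number from compound 3 to compound 4 (0.86 log units; beyond the scatter), and the size of this step carries over from the earlier core: the same change on two cores in this assay, a 9.8-fold higher number (0.99 log units; beyond the scatter) from compound 1 to compound 2 and a 7.2-fold higher number (0.86 log units; beyond the scatter) from compound 3 to compound 4, 1.4-fold (0.14 log units) apart, within the scatter of two such steps. The second change, 3-fluorophenyl in place of 4-chlorophenyl on an aromatic carbon, gives a 2.3-fold higher number from compound 2 to compound 4 (0.36 log units; beyond the scatter), and it also keeps its size when the group on the sulfonyl sulfur is different: the same change on two cores in this assay, a 3.2-fold higher number (0.50 log units; beyond the scatter) from compound 1 to compound 3 and a 2.3-fold higher number (0.36 log units; beyond the scatter) from compound 2 to compound 4, 1.4-fold (0.14 log units) apart, within the scatter of two such steps. Within these four compounds, each change therefore adds about the same step whichever form of the other group is present, but this rests on one set of four compounds in one assay and does not show that the same sizes would hold on a core that differs elsewhere, nor does it explain why the number rises.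

Every group shown on the sulfonyl sulfur is a substituted phenyl, so it remains open what a piperidine or a short alkyl chain would do there in this assay. Also open, on these data alone, is how an amine or a carboxylic acid would behave in place of 3-fluorophenyl on the aromatic carbon.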